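Aryl swap on the shared core: thiophene to dimethoxyphenyl

The source may hold more compounds than are shown below. What is called first, only, known or untested is meant among the compounds shown, and "the series" means these compounds.

The series rests on two measured compounds. Compound 1 `Cc1cc(O)c(C(C)C)cc1-c1cc(-c2ccccc2)c(C#N)c(=O)[nH]1` bears a phenyl on the core, and in a functional assay for inhibition, tested at 20 ug/mL (on this read-out lower numbers stand for a weaker effect and higher numbers for a stronger effect at the one concentration tested), compound 1 gives 22%. Compound 2 `Cc1cc(O)c(C(C)C)cc1-c1cc(-c2cccs2)c(C#N)c(=O)[nH]1` carries thiophen-2-yl in the same place, and in this assay compound 2 gives 26%. The only step between measured compounds, a number 4 percentage points higher from compound 1 to compound 2 (within the scatter), lies within the scatter, so compound 2 stands level with compound 1 on the numbers shown, and no order between the two can be read.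

Compound 3 `COc1ccc(-c2cc(-c3cc(C(C)C)c(O)cc3C)[nH]c(=O)c2C#N)c(OC)c1` is not yet measured. It differs from compound 2 in one place: 2,4-dimethoxyphenyl in place of thiophen-2-yl on an aromatic carbon. The step from compound 1 to compound 2 is the only one that bears on this change, as it too exchanges the group on that aromatic carbon, and it moved the read-out by an amount inside the scatter. Since no aryl exchange at this place has yet shifted the read-out beyond the scatter, the step of no change at the digits printed from compound 2 to compound 3 (within the scatter) is expected to be small, with no clear direction. For compound 3 the estimate in this assay is 26%, with a range from 10% to 45%.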

Compound 3, a percentage reported as inhibition, at one concentration (the size of the read-out at that concentration, not a potency): 27%
Estimate against measurement, compound 3: 1 percentage points below; the range from low to high includes it.
By their numbers in this assay, from the lowest: compounds 1, 2 and 3 (each within the scatter of the next).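

The aromatic carbon opposite the ring nitrogen now takes 2,4-dimethoxyphenyl, with 10 heavy atoms, in place of thiophen-2-yl, with 5 heavy atoms, and even this change in ring type and size gives in this assay only a number 1 percentage points higher from compound 2 to compound 3 (within the scatter). Set against the phenyl group, the same group gives a number 5 percentage points higher from compound 1 to compound 3 (within the scatter), so all three aromatic groups now stand level at this place, and no order among them can be read from these numbers. Nothing available bears on why these groups read alike.

All three groups are aromatic rings, so the compounds shown leave open whether a group of another kind on this carbon, such as an amine, a carboxylic acid or a saturated cyclohexyl ring, would move the read-out beyond the scatter. Also open, going by these compounds, is whether the read-out stays this level across such groups once the nitrile on the shared core gives way to a carboxamide, as all three compounds keep that nitrile.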